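Aminopyrazole ester series: swapping the para substituent

A few compounds are considered here, and "the series" means these few. Any claim that something is new, unique, unknown or untested is made for them only; others in the source may bear on it.

Measured so far:
compound 1 `CCOC(=O)c1cnn(-c2nc(-c3cccc(OC)c3OC)c(C#N)c(=O)n2C)c1N` 69 ug/mL
compound 2 `CCOC(=O)c1cnn(-c2nc(-c3ccc(N(C)C)cc3)c(C#N)c(=O)n2C)c1N` 115 ug/mL
compound 3 `Cn1c(NN)nc(-c2cccc(O)c2O)c(C#N)c1=O` 44 ug/mL

Compound 2 stands highest of the three numbers in a functional assay, with a stated time of 150 min; a higher number here means a weaker inhibitor, a lower number a stronger inhibitor. Its nearest neighbour is compound 1, and the step of a 1.7-fold higher number from compound 1 to compound 2 (0.22 log units; within the scatter) lies within the scatter, so the two are not separable on these data. Going by the values given here, compound 3 lies further off, with a number that is beyond the scatter from that of compound 2; compound 3 also differs from the other two in more than one place, so no single-change step connects it to them.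

Compound 4 `CCOC(=O)c1cnn(-c2nc(-c3ccc(Cl)cc3)c(C#N)c(=O)n2C)c1N` differs from compound 2 in one place: chloro in place of dimethylamino on an aromatic carbon. Among the compounds with values here, the one measured step that alters this ring, a 1.7-fold higher number from compound 1 to compound 2 (0.22 log units; within the scatter), exchanged the whole aryl group and stayed within the scatter. Within the data shown here, no measured pair shows a chloro entering or a dimethylamino leaving, so there is no direct precedent for the size or direction of this change. On the evidence of that single aryl swap, the step expected for compound 4 is a 1.2-fold lower number from compound 2 to compound 4 (0.06 log units; within the scatter), that is, none beyond the scatter. Compound 4 is therefore estimated at 100 ug/mL, with a range from 50 ug/mL to 220 ug/mL in this assay .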

Compound 4, half-maximal inhibitory concentration: 87 ug/mL
Compound 4: the middle estimate sits 1.1-fold (0.06 log units) above what was measured; low and high end bracket the measured number.
By their numbers in this assay, from the lowest: compounds 3, 1, 4 and 2 (each within the scatter of the next, the first and the last beyond it).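

In this assay, going by these compounds alone, chloro in place of dimethylamino on an aromatic carbon, para to a large group, gives a 1.3-fold lower number from compound 2 to compound 4 (0.12 log units; within the scatter); this is the only step that alters this substituent alone and keeps the rest of the phenyl ring unchanged, and it shows that this exchange, which leaves a smaller group with no hydrogen-bond acceptor, does not separate the two compounds. The wider exchange of the whole aryl group, 4-chlorophenyl in place of 2,3-dimethoxyphenyl, gives a 1.3-fold higher number from compound 1 to compound 4 (0.10 log units; within the scatter), so that together with a 1.7-fold higher number from compound 1 to compound 2 (0.22 log units; within the scatter) the three aryl groups in the aminopyrazole esters cannot be told apart in this assay. No measurement of any property of these groups is available to bear on these steps.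

Still open, as far as these compounds go, is whether any group at this place can move the number beyond the scatter, for instance a carboxylic acid, a primary amine or a longer alkoxy chain in place of chloro. Also open, from the compounds shown here alone, is whether the flat response to the aryl group holds once the ethyl ester of the shared core is replaced by a carboxylic acid or an amide.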